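A Shorter Side Chain on a Weakly Cytotoxic Pair

The source may report more compounds than this note shows. Statements on the series, on what has been measured and on what is new or still open speak of the compounds shown alone.

Measured in an ADME assay on THP-1 cells (Homo sapiens) for cytotoxicity, read by MTT assay, with a stated time of 72 h (on this read-out lower numbers stand for stronger inhibition and higher numbers for weaker inhibition), so far:
Compound 1 `COc1cc(/C=C/C(=O)c2c(O)c3ccccc3[nH]c2=O)ccc1O` gives 23300 nM
Compound 2 `O=C(/C=C/C=C/c1ccccc1)c1c(O)c2ccccc2[nH]c1=O` gives > 50000 nM as a limit, not a number

Compound 2 offers no exact number to start from. In this assay compound 2 reads > 50000 nM and this is a limit of the assay. Among the measured compounds shown here, the only exact reading so far belongs to compound 1, at 23300 nM in the same assay.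

Compound 3 `Cc1ccc(/C=C/C(=O)c2c(O)c3ccccc3[nH]c2=O)cc1` has not yet been measured. It differs from compound 2 by a single swap, with 4-methylphenyl in place of 2-phenylethenyl on a double-bonded chain carbon bound to a double-bonded chain carbon and the rest of the molecule unchanged. For the measured compounds named here, no measured pair shows what a swap of this kind does, so any expectation here is loose. A modest shift toward stronger inhibition is expected, resting only on the reading of compound 1 at 23300 nM as a guide to the range where an exact number might fall. The estimated move is an at least 1.5-fold lower number from compound 2 to compound 3 (0.19 log units; that floor lies within the scatter) and a second limit would be no surprise. Compound 3 is estimated at 32000 nM with an expected range from 12000 nM to 60000 nM in this assay for this first reading.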

Compound 3, half-maximal inhibitory concentration: > 50000 nM
Compound 3: no number, only a limit (the forecaster's own chance of this, stated with the estimate: 40%); middle value at least 1.5-fold (0.19 log units) away from the limit.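

In this assay, among the compounds shown here, the readings of compound 2 and compound 3 are both limits rather than exact numbers, so no step between them can be read: the limit of > 50000 nM in this assay, at which 2 of the 3 values shown sit.

The compounds shown leave open whether 4-methylphenyl in place of 2-phenylethenyl changes cytotoxicity at all, and in which direction.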